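Half-life at low pH: compound 2 to compound 3

The source may hold more compounds than are shown below. What is called first, only, known or untested is meant among the compounds shown, and "the series" means these compounds.

Two members of the series have been measured in a physicochemical assay for pharmacokinetics, at pH 2; on this read-out lower numbers stand for a shorter-lived compound and higher numbers for a longer-lived compound. Compound 1 `CC1(C)OC[C@@H](C/C=C\CCCC(=O)O)[C@@H](c2ccccc2O)O1` gives 0.0156 h in this assay, and compound 2 `O=C(O)CCC/C=C\C[C@@H]1CO[C@H](c2ccccc2Cl)O[C@@H]1c1ccccc1O` gives 19.7 h. Within the data shown here, compound 2 therefore stands highest of the two numbers; its only neighbour, compound 1, sits far lower, a gap well beyond the scatter. Compound 1 and compound 2 differ in more than one place, so their gap is not treated as a single step.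

Compound 3 `O=C(O)CCC/C=C\C[C@@H]1CO[C@H](C(F)(F)F)O[C@@H]1c1ccccc1O` is not yet measured. It differs from compound 2 in one place: trifluoromethyl in place of 2-chlorophenyl on a saturated ring carbon.

Among the measured compounds shown here, no measured step of this kind exists, so the expectation rests on the one-place change alone. The step expected here, a 7.6-fold higher number from compound 2 to compound 3 (0.88 log units; beyond the scatter), is upward and beyond the scatter. For compound 3 the estimate in this assay is 150 h, with a range from 30 h to 700 h. A number this high may come back only as a limit.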

Compound 3, half-life: 61300 h
Estimate against measurement, compound 3: 410-fold (2.61 log units) below; measured number outside the range, above it.
By their numbers in this assay, from the lowest: compound 1; then compound 2; then compound 3.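

Among these compounds, the saturated ring carbon between two ring oxygen atoms is the first place where a single change can be read: in this assay, trifluoromethyl in place of 2-chlorophenyl gives a 3100-fold higher number from compound 2 to compound 3 (3.49 log units; beyond the scatter), a large step. This one position can therefore shift the half-life at low pH strongly, even though the rest of the structure stays the same. The group that leaves carries a six-membered aromatic ring of carbon only and the group that enters carries no ring, but no measurement shown explains the step.

With a single step at this carbon, the loss of the aromatic ring and the arrival of fluorine cannot be separated. On these data alone, how a methyl or an unsubstituted phenyl group would stand at this position remains open, as does whether the step holds for other groups on the 2-hydroxyphenyl ring.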